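Sulfone Partners Around a Shared Core

The source may report more compounds than this note shows. Statements on the series, on what has been measured and on what is new or still open speak of the compounds shown alone.

Compound 1 `Cc1c(Cc2ccc(C(F)(F)F)cc2S(=O)(=O)c2ccccc2)c2c(n1CC(=O)O)CCNC2=O` — 13 nM
Compound 2 `Cc1c(Cc2cc(Br)ccc2S(=O)(=O)c2ccccc2)c2c(n1CC(=O)O)CCNC2=O` — 3.9 nM
Compound 3 `Cc1c(Cc2ccccc2S(=O)(=O)c2ccc(Cl)cc2)c2c(n1CC(=O)O)CCNC2=O` — 8.5 nM

Of the compounds shown here, three have been measured in a functional assay on CHO.K1 cells for antagonist activity at prostaglandin D2 receptor 2 (Homo sapiens), read by GTPgammaS binding, with a stated time of 1 h; a higher number here means a weaker inhibitor, a lower number a stronger inhibitor. Compound 3 holds the second highest of the three numbers. Compound 1 sits closest, within the scatter of compound 3, so no order is drawn between them. Compound 2, with the lowest number, lies beyond the scatter from compound 3. Compound 4 `Cc1c(Cc2ccccc2S(=O)(=O)N(C)Cc2ccccc2)c2c(n1CC(=O)O)CCNC2=O` differs from compound 3 in one place: benzyl(methyl)amino in place of 4-chlorophenyl on a sulfonyl sulfur. Within the data shown here, no measured pair shows a step of this kind, so nothing is known about its size. The step of a 1.8-fold higher number from compound 3 to compound 4 (0.25 log units; within the scatter) is estimated as a mild weakening, not far beyond the scatter. Compound 4 is expected to give about 15 nM in this assay, between 4 nM and 60 nM.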

Compound 4, half-maximal inhibitory concentration: 26 nM
Estimate against measurement, compound 4: 1.7-fold (0.24 log units) below, within the range that was stated.
By their numbers in this assay, from the lowest: compound 2; then compounds 3, 1 and 4 (each within the scatter of the next, the first and the last beyond it).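

In this assay, benzyl(methyl)amino in place of 4-chlorophenyl on a sulfonyl sulfur gives a 3.1-fold higher number from compound 3 to compound 4 (0.49 log units; beyond the scatter), the first step across a single change in this set. The sulfonyl sulfur therefore carries an amino group as well as an aryl group, at a modest cost, with compound 4 still at 26 nM. Nothing available explains this loss. The compounds shown leave open whether the step comes from the methyl, the benzyl or the nitrogen itself. They also leave open how a cyclic amine such as piperidine or morpholine on the same sulfur would compare.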